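The source may report more compounds than this note shows. Statements on the series, on what has been measured and on what is new or still open speak of the compounds shown alone.

The measured compounds:
compound 1, `Cc1c(Br)cc(C(=O)NC2CCCCCC2)c(=O)n1Cc1ccc(F)cc1`: > 10000 nM
compound 2, `Cc1nc(OCc2ccc(F)cc2)c(C(=O)NC2CCCCCC2)cc1Br`: 2100 nM
compound 3, `Cc1c(Br)cc(C(=O)NC2CCNCC2)c(=O)n1Cc1ccc(F)cc1`: > 10000 nM

In an assay on HEK293 cells for inhibition of Lysophosphatidylserine lipase ABHD12 (Homo sapiens), read by scintillation counting, with stated times of 30 min and 5 min (a higher number here means a weaker inhibitor, a lower number a stronger inhibitor), compound 1 gives only a limit, > 10000 nM, and so stands at the limit of > 10000 nM in this assay, at which 2 of the 3 values shown sit. Within the data shown here, compound 2 is the one compound with a numerical value, 2100 nM in this assay. Among the measured compounds shown here, the single measured step, a step that the two limits leave unreadable from compound 1 to compound 3, runs between two limits and its size is not readable.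

Compound 4, `Cc1c(-c2ccccc2)cc(C(=O)NC2CCCCCC2)c(=O)n1Cc1ccc(F)cc1`, differs from compound 1 by phenyl in place of bromo on an aromatic carbon. For the measured compounds named here, no measured step touches this aromatic carbon; the only known step lies at the amide-type nitrogen and is itself unreadable, so there is no measured basis for the direction or size of the change. Compound 4 is expected to remain close to the limit, with an estimated step that the limit leaves unreadable from compound 1 to compound 4. For compound 4 the estimate in this assay is 15000 nM, between 3000 nM and 60000 nM.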

Compound 4, half-maximal inhibitory concentration: > 10000 nM
Compound 4 ended at the assay's limit; the forecaster's own chance of this, stated with the estimate: 60%; the middle value does not contradict the limit.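

No step can be read between compound 1 and compound 4, because both values are limits: the limit of > 10000 nM in this assay, at which 3 of the 4 values shown sit.

The compounds shown leave open how much, and in which direction, phenyl in place of bromo changes inhibition.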